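A few compounds are considered here, and "the series" means these few. Any claim that something is new, unique, unknown or untested is made for them only; others in the source may bear on it.

Measured so far:

Compound 1, `Cn1ncc(Cl)c1-c1cc(C(=O)N[C@H]2CNCC[C@@H]2c2ccc(C(F)(F)F)cc2)oc1Cl`: 127 nM
Compound 2, `CC(=O)NCC[C@@H]1C[C@@H](c2ccc(F)c(F)c2)[C@H](NC(=O)c2cc(-c3c(Cl)cnn3C)c(Cl)o2)CN1`: 2.49 nM
Compound 3, `Cn1ncc(Cl)c1-c1cc(C(=O)N[C@@H]2CN[C@H](CCN3CCC(O)CC3)C[C@H]2c2ccc(Cl)c(Cl)c2)oc1Cl`: 5.99 nM

These three compounds share a core and were tested in an assay for inhibition of RAC-alpha serine/threonine-protein kinase (Homo sapiens), read by HTRF, with a stated time of 1 h; a higher number here means a weaker inhibitor, a lower number a stronger inhibitor. Compound 3 stands second highest of the three numbers. Its nearest neighbour is compound 2, whose number is lower by a gap beyond the usual scatter, so compound 2 reads as the stronger inhibitor of the two. Compound 1 is the furthest away, with a far higher number than compound 3, again well beyond the scatter.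

Compound 4, `Cn1ncc(Cl)c1-c1cc(C(=O)N[C@@H]2CN[C@H](CC(=O)NCC(O)CO)C[C@H]2c2ccc(Cl)c(Cl)c2)oc1Cl`, has not yet been measured. It differs from compound 3 in one place:

(2,3-dihydroxypropyl)carbamoyl in place of (4-hydroxypiperidin-1-yl)methyl on a saturated chain carbon bound to a saturated ring carbon

Both groups are polar tails on a saturated chain carbon bound to a saturated ring carbon, and compound 2 carries a different amide-bearing chain in that region while giving 2.49 nM in this assay. On that basis the step from compound 3 to compound 4 is expected to be small, of no clear direction, and likely within the scatter: a 1.2-fold lower number from compound 3 to compound 4 (0.08 log units; within the scatter).

Compound 4 is therefore estimated to give 5 nM in this assay, with a range from 1.5 nM to 15 nM.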

Compound 4, half-maximal inhibitory concentration: 3.13 nM
Beside the measured number, compound 4's estimate is 1.6-fold (0.20 log units) above it, and the stated range covers the measured number.
By their numbers in this assay, from the lowest: compounds 2, 4 and 3 (each within the scatter of the next, the first and the last beyond it); then compound 1.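

In this assay, putting (2,3-dihydroxypropyl)carbamoyl in place of (4-hydroxypiperidin-1-yl)methyl gives a 1.9-fold lower number from compound 3 to compound 4 (0.28 log units; within the scatter), so the two compounds cannot be told apart here. Among these compounds, this is the first direct reading at this place, on a saturated chain carbon bound to a saturated ring carbon, as the earlier compounds offered no pair differing in one place. It shows that a tail with no ring, a carbonyl and more hydrogen-bond donors is tolerated as well as one built on a six-membered non-aromatic ring, at least for this pair, and no measurement shown offers an explanation for that.

From the compounds shown here alone, one pair is a narrow basis, so it remains open whether a carboxylic acid, a primary amine or a longer chain ending in the same diol would fare the same at this place. It is also open how much any tail matters here, as no pair shown sets either group against a plain hydrogen.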